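Sulfonamide series: methoxy to ethyl on the sulfonyl aryl ring

The source may hold more compounds than are shown below. What is called first, only, known or untested is meant among the compounds shown, and "the series" means these compounds.

Compound 1 `O=S(=O)(Nc1ccc2oc(-c3ccccc3)nc2c1)c1ccccc1F` in an assay on cells for inhibition of HSP60/HSP10 (Homo sapiens), with a stated time of 60 min (on this read-out lower numbers stand for stronger inhibition and higher numbers for weaker inhibition), gives > 100000 nM, which is a limit of the assay and not a number. Compound 2 `COc1ccc(S(=O)(=O)Nc2ccc3oc(-c4ccccc4)nc3c2)cc1` in this assay gives > 100000 nM, likewise a limit. The step that the two limits leave unreadable from compound 1 to compound 2 is therefore not readable. Compound 2 stands at the limit of > 100000 nM in this assay, at which 2 of the 2 values shown sit. Compound 3 `CCc1ccc(S(=O)(=O)Nc2ccc3oc(-c4ccccc4)nc3c2)cc1` differs from compound 2 by ethyl in place of methoxy on an aromatic carbon. For the measured compounds named here, no measured step bears on this change in a readable way, so neither size nor direction can be taken from the data, and the two limits point to weak inhibition across the pair. Compound 3 is expected to give about 100000 nM, in a range from 30000 nM to 300000 nM, the step of a number no higher from compound 2 to compound 3 (the limit leaves the size open) being an estimate only.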

Compound 3, half-maximal inhibitory concentration: > 100000 nM
Compound 3: no number, only a limit (the forecaster's own chance of this, stated with the estimate: 85%); the middle value lies on the limit itself.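

In this assay no step can be read among compound 1, compound 2 and compound 3: all three values are limits, not numbers. The compounds shown leave open whether swapping methoxy for ethyl changes inhibition at all.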